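From cyclobutylamino to ethyl(methyl)amino on the carbonyl carbon

The source may hold more compounds than are shown below. What is called first, only, known or untested is meant among the compounds shown, and "the series" means these compounds.

In a functional assay on the whole organism with Mus musculus as the target (a lower number here means that less compound is needed, a higher number that more compound is needed for the effect), compound 2 `O=C(/C=C1\CCc2ccc(F)cc21)NC1CCC1` stands at > 100 mg/kg as a limit and not a number. That limit is the limit of > 100 mg/kg in this assay, at which 1 of the 2 values shown sits, and it leaves compound 2 without a measured position of its own. Compound 1 `CCNC(=O)/C=C1\CCc2ccc(F)cc21` gives 70 mg/kg in this assay on the same shared core. Compound 3 `CCN(C)C(=O)/C=C1\CCc2ccc(F)cc21` keeps that core and differs from compound 2 by ethyl(methyl)amino in place of cyclobutylamino on a carbonyl carbon with nothing else altered. Going by the values given here, the only measured step that bears on this change is an at least 1.4-fold higher number from compound 1 to compound 2 (0.15 log units; that floor lies within the scatter) and it concerns the same carbonyl substituent. Compound 1 at 70 mg/kg also carries an ethyl group, so compound 3 is expected to read near it, with a modest move toward a lower number. The step expected is an at least 1.2-fold lower number from compound 2 to compound 3 (0.09 log units; that floor lies within the scatter) by this estimate. For compound 3 the estimated value of 80 mg/kg comes with an expected range of 35 mg/kg to 180 mg/kg around it.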

Compound 3, dose for half-maximal effect: 100 mg/kg
Compound 3: middle estimate off by 1.3-fold (0.10 log units), on the low side; low and high end bracket the measured number.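

In this assay, ethyl(methyl)amino in place of cyclobutylamino on a carbonyl carbon gives a number no higher from compound 2 to compound 3 (the limit leaves the size open). In this assay, methyl in place of hydrogen on the amide-type nitrogen gives a 1.4-fold higher number from compound 1 to compound 3 (0.15 log units; within the scatter), so compound 1 and compound 3 cannot be told apart here, whether or not the amide hydrogen is present. The step from compound 2 to compound 3 cannot be read for size, because compound 2 has only a limit and not a number: the limit of > 100 mg/kg in this assay, at which 1 of the 3 values shown sits.

The compounds shown leave open whether any other group on the carbonyl carbon, such as a morpholine or a longer chain like butylamino, would shift the dose beyond the scatter. They also leave open where compound 2 would fall if it had a measured number.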